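Para-Fluoro on the Anilino Ring: Vero Cytotoxicity Expectation

This account rests on a few compounds, and the source may have more. Where it says the series, first, only, none or still open, it means among the compounds named here.

The measured compounds:
Compound 1 `N=c1c2ncnc(Nc3ccccc3)c2ncn1NC(=O)c1ccncc1`: 4.37 ug/mL
Compound 2 `N=c1c2ncnc(Nc3ccccc3)c2ncn1NC(=O)c1ccccc1`: 2.35 ug/mL
Compound 3 `N=c1c2ncnc(Nc3ccccc3)c2ncn1NC(=O)c1ccco1`: "not determined" (no result reported)

In an ADME assay on Vero cells (Chlorocebus sabaeus) for cytotoxicity (a higher number here means that more compound is needed for the effect, a lower number that less compound is needed), compound 1 gives 4.37 ug/mL and compound 2 gives 2.35 ug/mL. Compound 3 carries a furan-2-yl on the carbonyl carbon, and in this assay compound 3 stands as "not determined" (no result reported), so no number is reported for it. Going by the values given here, compound 2 holds the lowest of the two numbers available, but its only neighbour is compound 1, and the step of a 1.9-fold lower number from compound 1 to compound 2 (0.27 log units; within the scatter) lies within the scatter, so the two are not separated on this read-out.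

Compound 4 `N=c1c2ncnc(Nc3ccc(F)cc3)c2ncn1NC(=O)c1ccccc1` is not yet measured. It differs from compound 2 by fluoro in place of hydrogen on an aromatic carbon. Among the compounds with values here, no measured step touches the anilino part of the shared core; the single step known, a 1.9-fold lower number from compound 1 to compound 2 (0.27 log units; within the scatter), concerns the group on the carbonyl carbon and was itself within the scatter. There is therefore no basis for expecting a shift beyond the scatter in this assay in either direction.

The estimate for compound 4 is 2.6 ug/mL, with a range from 1.2 ug/mL to 5.5 ug/mL, which means an expected step of a 1.1-fold higher number from compound 2 to compound 4 (0.04 log units; within the scatter) and is taken to reflect no change beyond the scatter.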

Compound 4, half-maximal effective concentration: 3.05 ug/mL
Compound 4: middle estimate off by 1.2-fold (0.07 log units), on the low side; measured number inside the range.
By their numbers in this assay, from the lowest: compounds 2, 4 and 1 (each within the scatter of the next).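

Going by these compounds alone, the step of a 1.3-fold higher number from compound 2 to compound 4 (0.11 log units; within the scatter) is the first reading at the anilino part of the shared core, and in this assay it shows that fluoro on this aromatic carbon, para to a large group, leaves compound 4 not separated from its parent on this read-out. Within the data shown here, the one earlier step, a 1.9-fold lower number from compound 1 to compound 2 (0.27 log units; within the scatter), concerned only the group on the carbonyl carbon, so one change in each of these two parts has now been read and neither gives a shift beyond the scatter. No evidence is at hand that bears on this result.

The compounds shown leave open whether another group in the same place, such as methoxy, trifluoromethyl or an amine, would give a step beyond the scatter, and whether fluoro on another carbon of that ring would read as this one does. They also leave open whether the change from phenyl to 4-fluorophenyl would read the same with pyridin-4-yl or furan-2-yl in place of phenyl on the carbonyl carbon.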